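A few compounds are considered here, and "the series" means these few. Any claim that something is new, unique, unknown or untested is made for them only; others in the source may bear on it.

- Compound 1 `CCCSC(=O)COC(=O)C1=C2C(=NC1=O)c1cccc3cccc2c13`: 25200 nM
- Compound 2 `O=C(COC(=O)C1=C2C(=NC1=O)c1cccc3cccc2c13)OCC(F)(F)C(F)(F)F`: 48300 nM
- Compound 3 `C=CCSc1ccc2c3c(cccc13)C1=NC(=O)C(C(=O)OCC(=O)SCCC)=C12`: > 100000 nM

In an ADME assay on WI-38 cells (Homo sapiens) for antiproliferative activity, read by sulforhodamine B assay, with a stated time of 72 h (on this read-out higher numbers stand for weaker inhibition and lower numbers for stronger inhibition), compound 1 gives 25200 nM. Going by the values given here, compound 1 and compound 2 hold the only two exact numbers, and they cannot be told apart: the step is a 1.9-fold higher number from compound 1 to compound 2 (0.28 log units; within the scatter). Compound 3 reads > 100000 nM, which is a limit of the assay.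

Compound 4 `CCCSC(=O)COC(=O)C1=C2C(=NC1=O)c1cccc3c(SCCC)ccc2c13` is not yet measured. It carries propylsulfanyl in place of hydrogen on an aromatic carbon of compound 1: propylsulfanyl in place of hydrogen on an aromatic carbon.

The closest guide is an at least 3.9-fold higher number from compound 1 to compound 3 (0.59 log units; beyond the scatter), a swap of allylsulfanyl for hydrogen on an aromatic carbon, so a move in the same direction is expected for compound 4 in this assay. That guide is a single step, and its size is left open by the limit of > 100000 nM in this assay, at which 1 of the 3 values shown sits. The other step, a 1.9-fold higher number from compound 1 to compound 2 (0.28 log units; within the scatter), changes a different part of the molecule and says little here. The expected step is a 2.8-fold higher number from compound 1 to compound 4 (0.44 log units; beyond the scatter). Compound 4 is estimated at 70000 nM, with an expected range of 25000 nM to 150000 nM.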

Compound 4, half-maximal inhibitory concentration: > 100000 nM
Compound 4: only a limit was reported; the forecaster's own chance of this, stated with the estimate: 40%; middle value at least 1.4-fold (0.15 log units) from the limit.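

In this assay, propylsulfanyl on this aromatic carbon of the core weakens inhibition, the same direction seen with allylsulfanyl: an at least 3.9-fold higher number from compound 1 to compound 4 (0.59 log units; beyond the scatter). The rise therefore does not depend on the carbon-carbon double bond of allylsulfanyl, as the saturated propylsulfanyl chain gives it too, and it now rests on two compounds rather than one. Any difference between compound 3 and compound 4 cannot be read, since each reading is a limit and not a number: the limit of > 100000 nM in this assay, at which 2 of the 4 values shown sit.

Going by these compounds, the true size of the rise with either chain remains unknown. On these data alone, it is also open whether a group without sulfur on the same carbon, such as an amine or a methoxy group, would shift the reading of compound 1, 25200 nM, in the same way.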